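Chain shortening from compound 2 to compound 3

The source may report more compounds than this note shows. Statements on the series, on what has been measured and on what is new or still open speak of the compounds shown alone.

In an ADME assay on HEK293 cells (Homo sapiens) for inhibition, read by MTT assay, with stated times of 18 h and 4 h (on this read-out lower numbers stand for stronger inhibition and higher numbers for weaker inhibition), compound 1 `CCCCCCCCCCOP(=O)(O)OCCSC(=S)N1CCCCCC1` gives 70000 nM. Compound 2 `CCCCCCCCOP(=O)(O)OCCSC(=S)N1CCCCCC1` gives > 100000 nM, which is a limit of the assay and not a number. Compound 3 `CCCCCCOP(=O)(O)OCCSC(=S)N1CCCCCC1` differs from it by hydrogen in place of ethyl on a saturated chain carbon, six bonds along the chain from an oxygen on an unsaturated carbon. Within the data shown here, the one measured step that bears on this is the same exchange eight bonds along the chain, an at least 1.4-fold higher number from compound 1 to compound 2 (0.15 log units; that floor lies within the scatter). Weaker inhibition or no change beyond the scatter is therefore expected, with an estimated step that the limit leaves unreadable from compound 2 to compound 3. For compound 3 the estimate is 160000 nM, with an expected range of 100000 nM to 400000 nM.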

Compound 3, half-maximal inhibitory concentration: 70500 nM
The estimate for compound 3 lay 2.3-fold (0.36 log units) above the measured number; measured number below the stated range.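

In this assay, hydrogen in place of ethyl, six bonds along the chain from an oxygen on an unsaturated carbon, gives an at least 1.4-fold lower number from compound 2 to compound 3 (0.15 log units; that floor lies within the scatter) and so points the opposite way to the same exchange eight bonds along. Hydrogen in place of butyl gives a 1.0-fold higher number from compound 1 to compound 3 (0.00 log units; within the scatter) and so leaves these two compounds reading alike despite the shorter chain. Compound 2 stands at a limit of the assay, not a number, and the size of its steps stays unread: the limit of > 100000 nM in this assay, at which 1 of the 3 values shown sits.

From the compounds shown here alone, whether a longer chain or an amine on the chain would move the number beyond the scatter stays open.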